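A Nitro Group Added to an Inactive Hydrazone

This account rests on a few compounds, and the source may have more. Where it says the series, first, only, none or still open, it means among the compounds named here.

Compound 1, `CCOC(=O)N1CCC(=NNC(=O)c2ccc(C)cc2)CC1`, in a functional assay on A549 cells (Homo sapiens) for cytotoxicity, read by MTT assay, with a stated time of 24 h (a lower number here means a stronger inhibitor, a higher number a weaker inhibitor), gives > 400000 nM, which is a limit of the assay rather than a number.
Compound 2, `CCOC(=O)N1CCC(=NNC(=O)c2ccc([N+](=O)[O-])cc2[N+](=O)[O-])CC1`, gives 27300000 nM in this assay.
Compound 3, `O=C(NN=C1CC(c2ccccc2)NC(c2ccccc2)C1)c1ccccc1`, gives > 400000 nM in this assay, again a limit rather than a number.

Compound 3 therefore stands at the edge of what this assay can report: its reading is a limit, and the same holds for compound 1, so that (the limit of > 400000 nM in this assay, at which 2 of the 3 values shown sit). Only compound 2 returns an actual number, and a weak one. The change to compound 4, `O=C(NN=C1CC(c2ccccc2)NC(c2ccccc2)C1)c1ccc([N+](=O)[O-])cc1`, consists of nitro in place of hydrogen on an aromatic carbon. Among the measured compounds shown here, no pair of measured compounds differs in exactly this way, so no measured step guides the expectation. The values of compound 1 and compound 2 show that a compound bearing nitro groups did return a number where a compound bearing a methyl group stayed at the limit, but those two differ in more than one place, so nothing firm follows from them. The expected step is a step that the limit leaves unreadable from compound 3 to compound 4, and the result may again come back as a limit. The estimate for compound 4 is 1500000 nM, with a range from 400000 nM to 30000000 nM.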

Compound 4, half-maximal inhibitory concentration: > 400000 nM
Compound 4 was reported as a limit; the forecaster's own chance of this, stated with the estimate: 50%; the middle value does not contradict the limit.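

Compound 3 and compound 4 both come back from this assay as limits rather than numbers, so no step can be read between them. The compounds shown leave open whether nitro in place of hydrogen on this aromatic carbon changes the reading at all, as most of them sit at one limit: the limit of > 400000 nM in this assay, at which 3 of the 4 values shown sit.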